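Extending a Methoxymethyl Group on a Corticotropin-Releasing Factor Ligand

The source may report more compounds than this note shows. Statements on the series, on what has been measured and on what is new or still open speak of the compounds shown alone.

Measured compounds:
Compound 1, `CCc1nn2c(-c3c(OC)cccc3OC)cccc2c1N(CC1CCOCC1)CC1CC1`: 105 nM
Compound 2, `CCc1nn2c(-c3c(OC)cc(COC)cc3OC)cccc2c1N(CC1CCOCC1)CC1CC1`: 50 nM

Both compounds were tested in an assay on HEK293 cells for displacement of a labelled ligand from corticotropin-releasing factor receptor 1 (Homo sapiens), read by scintillation counting, with a stated time of 2 h; on this read-out lower numbers stand for stronger inhibition and higher numbers for weaker inhibition. Compound 1 gives 105 nM and compound 2 gives 50 nM, so compound 2 stands at the lowest of the two numbers. For the measured compounds named here, the one measured step, methoxymethyl in place of hydrogen on an aromatic carbon, gave a 2.1-fold lower number from compound 1 to compound 2 (0.32 log units; beyond the scatter).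

Compound 3, `CCOCc1cc(OC)c(-c2cccc3c(N(CC4CCOCC4)CC4CC4)c(CC)nn23)c(OC)c1`, differs from compound 2 by methyl in place of hydrogen on a saturated chain carbon bound to an oxygen on a saturated carbon; the same difference, cut one bond further out, reads methoxymethyl to ethoxymethyl. Going by the values given here, no measured step covers this change. Among the compounds with values here, the only step available, a 2.1-fold lower number from compound 1 to compound 2 (0.32 log units; beyond the scatter), put the methoxymethyl group in place and was modest; adding a methyl to its outer end is a smaller change than that, so a step within the scatter, in either direction, is the expectation for a 1.1-fold lower number from compound 2 to compound 3 (0.05 log units; within the scatter). Compound 3 is therefore estimated at 45 nM, within a range from 20 nM to 110 nM.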

Compound 3, half-maximal inhibitory concentration: 49 nM
Compound 3: middle estimate off by 1.1-fold (0.04 log units), on the low side; the measured number falls inside the stated range.
By their numbers in this assay, from the lowest: compounds 3 and 2 (each within the scatter of the next); then compound 1.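

In this assay, the methyl that turns methoxymethyl into ethoxymethyl gives a 1.0-fold lower number from compound 2 to compound 3 (0.01 log units; within the scatter), so the two compounds cannot be told apart and this outer end of the group accepts one more carbon without a measurable cost. The larger group also keeps the gain over the core without a substituent at this aromatic carbon, with a 2.1-fold lower number from compound 1 to compound 3 (0.33 log units; beyond the scatter) for ethoxymethyl in place of hydrogen. Nothing available explains why the number holds when this methyl is added.

On these data alone, it remains open how far this tolerance extends, for instance to a longer chain such as propoxymethyl. It is also unknown how the number would respond if the ether gave way to an amine or a carboxylic acid at the same aromatic carbon.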